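Halogen placement on the phenoxy ring: a bromo variant

This account rests on a few compounds, and the source may have more. Where it says the series, first, only, none or still open, it means among the compounds named here.

The parent of the set is compound 1 `NC1=NC2(CCOCC2)N(OCCCOc2ccccc2)C(N)=N1`. In a functional assay on A549 cells (Homo sapiens) for antiproliferative activity, read by MTT assay, with a stated time of 72 h (on this read-out lower numbers stand for stronger inhibition and higher numbers for weaker inhibition), compound 1 gives 1080 nM, the highest of the three numbers recorded so far. Two halogenated analogues sit below it. Compound 2 `NC1=NC2(CCOCC2)N(OCCCOc2ccc(Cl)cc2)C(N)=N1` gives 360 nM in this assay, a step of a 3.0-fold lower number from compound 1 to compound 2 (0.48 log units; beyond the scatter). Compound 3 `NC1=NC2(CCOCC2)N(OCCCOc2ccccc2Br)C(N)=N1` gives 160 nM, a step of a 6.8-fold lower number from compound 1 to compound 3 (0.83 log units; beyond the scatter). Between the two halogenated compounds the step is a 2.3-fold lower number from compound 2 to compound 3 (0.35 log units; beyond the scatter).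

The next compound, compound 4 `NC1=NC2(CCOCC2)N(OCCCOc2cccc(Br)c2)C(N)=N1`, differs from compound 1 by bromo in place of hydrogen on an aromatic carbon. Both measured halogen entries onto the phenoxy ring lowered the number beyond the scatter, and the change to compound 4 is the same bromo entry at another place on the ring. Because the chloro entry gave a 3.0-fold lower number from compound 1 to compound 2 (0.48 log units; beyond the scatter) and the bromo entry gave a 6.8-fold lower number from compound 1 to compound 3 (0.83 log units; beyond the scatter), a lower number is expected for compound 4, of a size between those two steps; nothing measured here separates one place on the ring from another for the same halogen. The expected step is a 3.6-fold lower number from compound 1 to compound 4 (0.56 log units; beyond the scatter). Compound 4 is therefore estimated at 300 nM, with a range from 150 nM to 650 nM.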

Compound 4, half-maximal inhibitory concentration: 160 nM
For compound 4 the middle estimate is 1.9-fold (0.27 log units) above the measured one, within the range that was stated.
By their numbers in this assay, from the lowest: compounds 3 and 4 (each within the scatter of the next); then compound 2; then compound 1.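

In this assay, shifting the bromo group from the 2-bromophenyl of compound 3 to the 3-bromophenyl of compound 4 gives no change at the digits printed from compound 3 to compound 4 (within the scatter), so this read-out does not separate these two places on the phenoxy ring for bromo. The bromo entry now has two readings on the parent, a 6.8-fold lower number from compound 1 to compound 3 (0.83 log units; beyond the scatter) and a 6.8-fold lower number from compound 1 to compound 4 (0.83 log units; beyond the scatter), and the gain over the unsubstituted phenoxy group of compound 1 therefore holds at both places tested. The pair with the chloro compound gives a 2.3-fold lower number from compound 2 to compound 4 (0.35 log units; beyond the scatter), but this step changes the halogen and its place together, so it cannot assign the difference to either one.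

The compounds shown leave open whether chloro would behave like bromo at these places, and whether bromo at the place occupied by chloro in compound 2 would match compounds 3 and 4; they also leave open how a methoxy group, a trifluoromethyl group or an amine on the ring, or a longer chain to the phenoxy group, would read in this assay. No available evidence bears on the reason for these steps.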